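Solubility notes: tert-butyl for chloro on compound 3

The compounds below may be only part of what the source reports. "The series", "measured", "known", "first", "only" and "open" are said of these compounds alone.

Compound 3 `CCOC(=O)c1c(-c2ccc(Cl)cc2)[nH]c2cccc(OC)c2c1=O` stands at a limit in a physicochemical assay for solubility, in phosphate buffer, at pH 7.4; a lower number here means a less soluble compound, a higher number a more soluble compound: compound 3 gives > 100000 nM, which is a limit of the assay and not a number. Compound 1 `CCOC(=O)c1c(-c2cccc(Cl)c2)[nH]c2cccc(OC)c2c1=O` likewise gives the limit > 100000 nM. Compound 2 `CCOC(=O)c1c(-c2ccc(OC)cc2)[nH]c2cccc(OC)c2c1=O` also gives the limit > 100000 nM. All three values thus sit at the limit of > 100000 nM in this assay, at which 3 of the 3 values shown sit, and the steps a step that the two limits leave unreadable from compound 1 to compound 2, a step that the two limits leave unreadable from compound 1 to compound 3 and a step that the two limits leave unreadable from compound 2 to compound 3 cannot be read for size or direction. Compound 4 `CCOC(=O)c1c(-c2ccc(C(C)(C)C)cc2)[nH]c2cccc(OC)c2c1=O` differs from compound 3 by tert-butyl in place of chloro on an aromatic carbon. The measured steps give no readable size to work from, so the counted difference is the only footing. Compound 4 is expected to come in under the limit. The expected step is an at least 3.3-fold lower number from compound 3 to compound 4 (0.52 log units; beyond the scatter). The estimate for compound 4 is 30000 nM, ranging from 5000 nM to 150000 nM.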

Compound 4, solubility: 1000 nM
The estimate for compound 4 lay 30-fold (1.48 log units) above the measured number, outside the stated range (below it).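

At this position this assay now gives its first readable steps, both large: (an at least 100-fold lower number from compound 3 to compound 4 (2.00 log units; beyond the scatter)) and (an at least 100-fold lower number from compound 2 to compound 4 (2.00 log units; beyond the scatter)). The group on this aromatic carbon can therefore move the read-out, which the swaps among chloro, methoxy and the shifted chlorine could not show. Those earlier steps cannot be read: (the limit of > 100000 nM in this assay, at which 3 of the 4 values shown sit). Both new steps start from a limit and fix only a least size. Open, going by these compounds, is whether an amine, a carboxylic acid or a longer chain in place of tert-butyl would stay at the limit or fall towards compound 4.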